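This account rests on a few compounds, and the source may have more. Where it says the series, first, only, none or still open, it means among the compounds named here.

Measured compounds:
- compound 1, `COc1cccc(-c2cc(-c3cc(C(C)C)c(O)cc3C)[nH]c(=O)c2C#N)c1`: 30% in a functional assay for inhibition, tested at 40 ug/mL; a lower number here means a weaker effect, a higher number a stronger effect of the compound at the concentration tested
- compound 2, `COc1ccc(-c2cc(-c3cc(C(C)C)c(O)cc3C)[nH]c(=O)c2C#N)cc1OC`: 44% in this assay

Compound 1 stands lowest of the two numbers shown; its nearest neighbour is compound 2, with the step of a number 14 percentage points higher from compound 1 to compound 2 (beyond the scatter) going beyond the scatter. Compound 3, `Cc1cc(O)c(C(C)C)cc1-c1cc(-c2ccccc2[N+](=O)[O-])c(C#N)c(=O)[nH]1`, differs from compound 1 by 2-nitrophenyl in place of 3-methoxyphenyl on an aromatic carbon. Within the data shown here, the single measured step, a number 14 percentage points higher from compound 1 to compound 2 (beyond the scatter), concerns a methoxy added on the same ring and does not touch the change to a 2-nitrophenyl, so nothing measured bears directly on the step to compound 3. With no comparable step shown, the read-out for compound 3 in this assay is expected to stay near that of compound 1, and the expected step is a number 2 percentage points higher from compound 1 to compound 3 (within the scatter), which is not beyond the scatter. Compound 3 is estimated at 32%, within 12% to 55%.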

Compound 3, a percentage reported as inhibition, at one concentration (the size of the read-out at that concentration, not a potency): 25.5%
For compound 3 the middle estimate is 6.5 percentage points above the measured one; the measured number falls inside the stated range.
By their numbers in this assay, from the lowest: compounds 3 and 1 (each within the scatter of the next); then compound 2.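

In this assay, the place opposite the ring nitrogen accepts 2-nitrophenyl in place of 3-methoxyphenyl with no readable change (a number 4.5 percentage points lower from compound 1 to compound 3 (within the scatter)), so these two aryl groups cannot be told apart here despite their different substituents and substitution patterns. Replacing 3,4-dimethoxyphenyl with 2-nitrophenyl at the same place does separate the pair (a number 18.5 percentage points lower from compound 2 to compound 3 (beyond the scatter)), which leaves compound 2 as the only one of the three clear of the other two. No measurement at hand accounts for either step.

Still open, going by these compounds, is whether the placement of the nitro group matters, since a 4-nitrophenyl or 3-nitrophenyl group would test this directly. Also open, on these data alone, is how an unsubstituted phenyl, or a phenyl carrying an amine or a carboxylic acid, would read at this place.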